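Aryl swap on the aromatic nitrogen: compound 3 to compound 4

The compounds below may be only part of what the source reports. "The series", "measured", "known", "first", "only" and "open" are said of these compounds alone.

Compound 3 `Cn1ncc2c(NC(=O)NCc3cc(C(C)(C)C)nn3-c3cccc(C(F)(F)F)c3)cccc21` gives 0.6 nM in an assay on CHO-K1 cells for antagonist activity at transient receptor potential cation channel subfamily V member 1 (Homo sapiens), read by FLIPR and calcium flux, with a stated time of 6 min (on this read-out higher numbers stand for weaker inhibition and lower numbers for stronger inhibition), the lowest of the three numbers; compound 1 `Cn1ncc2c(NC(=O)NCc3cc(C(F)(F)F)nn3-c3cccc(C(F)(F)F)c3)cccc21` gives 1.4 nM and compound 2 `CC(C)(C)c1ccc(-n2nc(C(C)(C)C)cc2CNC(=O)Nc2cccc3[nH]ncc23)cc1` gives 40 nM. Going by the values given here, the only one-place step in the set, a 2.3-fold lower number from compound 1 to compound 3 (0.37 log units; beyond the scatter), favoured tert-butyl. Compound 4 `Cn1ncc2c(NC(=O)NCc3cc(C(C)(C)C)nn3-c3ccc(C(C)(C)C)cc3)cccc21` differs from compound 3 by 4-(tert-butyl)phenyl in place of 3-(trifluoromethyl)phenyl on an aromatic nitrogen. Among the compounds with values here, no measured step bears directly on this change; compound 2, which carries the same 4-(tert-butyl)phenyl and tert-butyl pair on a different core, stands well above compound 3 in this assay, but its core also differs, so its value is only a loose pointer. For compound 4 a moderate rise in the number is therefore expected, a 5.0-fold higher number from compound 3 to compound 4 (0.70 log units; beyond the scatter). Compound 4 is estimated at 3 nM, range 0.8 nM to 12 nM.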

Compound 4, inhibition constant: 46.3 nM
The estimate for compound 4 lay 15-fold (1.19 log units) below the measured number; the measured number lies above the stated range.
By their numbers in this assay, from the lowest: compound 3; then compound 1; then compounds 2 and 4 (each within the scatter of the next).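

With tert-butyl held on the five-membered ring, the aryl group on its nitrogen strongly sets the number in this assay, with a 77-fold higher number from compound 3 to compound 4 (1.89 log units; beyond the scatter) for 4-(tert-butyl)phenyl in place of 3-(trifluoromethyl)phenyl, though both groups count the same heavy atoms. With 4-(tert-butyl)phenyl in place, methyl in place of hydrogen on the core nitrogen gives a 1.2-fold higher number from compound 2 to compound 4 (0.06 log units; within the scatter). Nothing available explains the aryl step.

The step changes both substituent and ring position, so their shares remain unseparated. As far as these compounds go, what a chlorine atom or a methoxy group on that phenyl ring would give remains open.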